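This account rests on a few compounds, and the source may have more. Where it says the series, first, only, none or still open, it means among the compounds named here.

Three compounds that share a ketone-linked chain ending in a phenyl ring have been tested in an assay on HEK-293T cells for inhibition of diacylglycerol lipase-alpha (Homo sapiens), read by colorimetric assay; on this read-out lower numbers stand for stronger inhibition and higher numbers for weaker inhibition. Compound 1 `O=C(CCCCCCc1ccccc1)c1nc(C(F)(F)F)co1` gives 214 nM. Compound 2 `COc1coc(C(=O)CCCCCCc2ccccc2)n1` reaches only the assay limit of > 10000 nM. Compound 3 `COc1ccc(-c2cnc(C(=O)CCCCCCc3ccccc3)o2)nc1` likewise reaches only the assay limit of > 10000 nM. Compound 1 differs from compound 2 by trifluoromethyl in place of methoxy on an aromatic carbon, a change that gave an at least 46-fold lower number from compound 2 to compound 1 (1.66 log units; beyond the scatter); its true size is uncertain because compound 2 sits at the limit of > 10000 nM in this assay, at which 2 of the 3 values shown sit. Compound 4 `O=C(CCCCCCc1ccccc1)c1ncc(-c2ccc(C(F)(F)F)cn2)o1` arises from compound 3 by trifluoromethyl in place of methoxy on an aromatic carbon. The difference between the two cores is not broken down here, and in compound 4 the change sits on a six-membered aromatic ring with 1 nitrogen, two atoms from the ring nitrogen and para to a large group, whereas in compound 1 it sits on a five-membered aromatic ring with 1 nitrogen and 1 oxygen, next to the ring nitrogen; it is therefore the same kind of change, not the same change. This change is expected to give an at least 5.0-fold lower number from compound 3 to compound 4 (0.69 log units; beyond the scatter), resting on an at least 46-fold lower number from compound 2 to compound 1 (1.66 log units; beyond the scatter). Compound 4 is estimated at 2000 nM, somewhere between 300 nM and 10000 nM.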

Compound 4, half-maximal inhibitory concentration: > 10000 nM
Compound 4 ended at the assay's limit; the forecaster's own chance of this, stated with the estimate: 35%; at least 5.0-fold (0.69 log units) between middle value and limit.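

Compound 3 and compound 4 both sit at a limit, so no step between them can be read: the limit of > 10000 nM in this assay, at which 3 of the 4 values shown sit.

The compounds shown leave open whether trifluoromethyl in place of methoxy changes inhibition at all on the core shared by compound 3 and compound 4.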